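Solubility After an Isobutyl to 4-Fluorophenoxy Exchange

The compounds below may be only part of what the source reports. "The series", "measured", "known", "first", "only" and "open" are said of these compounds alone.

Compound 1 `CC(C)Cc1ccc2c(NCCCNCc3ccco3)ccnc2c1` and two close relatives were measured in a physicochemical assay for solubility, with a stated time of 18 h, at pH 7.4; a lower number here means a less soluble compound, a higher number a more soluble compound. In this assay compound 1 gives 4200 nM. Compound 2 `Fc1ccc(Oc2ccc3c(NCCCNCc4ccco4)ccnc3c2)cc1` carries 4-fluorophenoxy in place of isobutyl on an aromatic carbon, and in this assay compound 2 gives 14500 nM, which is a 3.5-fold higher number from compound 1 to compound 2 (0.54 log units; beyond the scatter). Compound 3 `COc1ccc(F)cc1CNCCCNc1ccnc2cc(CC(C)C)ccc12` instead has 5-fluoro-2-methoxyphenyl in place of furan-2-yl on a saturated chain carbon bound to an amine nitrogen; in this assay compound 3 gives 4200 nM, and no change at the digits printed from compound 1 to compound 3 (within the scatter). Compound 3 therefore stands level with compound 1 at the digits shown, the two together the lowest of the three numbers, with compound 2 furthest from it.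

Compound 4 `COc1ccc(F)cc1CNCCCNc1ccnc2cc(Oc3ccc(F)cc3)ccc12` differs from compound 3 in one place: 4-fluorophenoxy in place of isobutyl on an aromatic carbon. The same exchange has been seen once already, where a 3.5-fold higher number from compound 1 to compound 2 (0.54 log units; beyond the scatter). Among the measured compounds shown here, no other measured step bears on it. A step of similar size and direction is therefore expected in this assay, namely a 3.5-fold higher number from compound 3 to compound 4 (0.54 log units; beyond the scatter). Compound 4 is expected to give 14500 nM in this assay, with a range from 7000 nM to 30000 nM.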

Compound 4, solubility: 14500 nM
For compound 4 middle estimate and measured number coincide at the digits printed; low and high end bracket the measured number.
By their numbers in this assay, from the lowest: compounds 1 and 3 (each within the scatter of the next); then compounds 2 and 4 (each within the scatter of the next).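

In this assay, the exchange of isobutyl for 4-fluorophenoxy on this aromatic carbon again gives a 3.5-fold higher number from compound 3 to compound 4 (0.54 log units; beyond the scatter), so the step is now seen with 5-fluoro-2-methoxyphenyl as well as with furan-2-yl on the saturated chain carbon. The exchange of furan-2-yl for 5-fluoro-2-methoxyphenyl likewise reads the same with 4-fluorophenoxy as it did with isobutyl, with no change at the digits printed from compound 2 to compound 4 (within the scatter). Nothing available explains the higher number that accompanies 4-fluorophenoxy.

The compounds shown leave open which part of 4-fluorophenoxy goes with the step, since a plain phenoxy, a 4-fluorophenyl or a morpholine on this aromatic carbon does not appear among them. Also open, as far as these compounds go, is whether the two steps would hold on a longer saturated chain.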